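A few compounds are considered here, and "the series" means these few. Any claim that something is new, unique, unknown or untested is made for them only; others in the source may bear on it.

Compound 1 `O=C(NC1CCC(CN2CCN(c3cc(=O)c4cc(C(F)(F)F)cc([N+](=O)[O-])c4s3)CC2)CC1)c1ccccc1` and compound 2 `Cc1ccc(C(=O)OC2CCC(CN3CCN(c4cc(=O)c5cc(C(F)(F)F)cc([N+](=O)[O-])c5s4)CC3)CC2)cc1` share a core and differ only on a saturated ring carbon. In an ADME assay on cells (Hepatocyte, Mus musculus) for metabolic stability, with a stated time of 30 min (a lower number here means that less of the compound is left, a higher number that more of the compound is left), compound 1 gives 90.6%, while compound 2 gives 18%, the lowest of the two numbers; the step is a number 72.6 percentage points lower from compound 1 to compound 2 (beyond the scatter). Compound 3 `O=C(OC1CCC(CN2CCN(c3cc(=O)c4cc(C(F)(F)F)cc([N+](=O)[O-])c4s3)CC2)CC1)C1CCCCC1` keeps the ester of compound 2 and differs from it by cyclohexyl in place of 4-methylphenyl on a carbonyl carbon. Among the compounds with values here, the only measured step, from compound 1 to compound 2, swaps the linking group rather than the ring on the carbonyl, so it bears only loosely here. Without a measured step for this kind of change, the expected step is a number 3 percentage points lower from compound 2 to compound 3 (within the scatter), and compound 3 is estimated at 15%, within 4% to 40%.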

Compound 3, percent of the compound remaining: 1.2%
Beside the measured number, compound 3's estimate is 13.8 percentage points above it; the whole stated range lies above it.
By their numbers in this assay, from the lowest: compound 3; then compound 2; then compound 1.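

The linking group is not the only part that counts here: with the ester kept, cyclohexyl in place of 4-methylphenyl on the carbonyl carbon still moves the number in this assay, giving a number 16.8 percentage points lower from compound 2 to compound 3 (beyond the scatter) as a modest step. Set against the amide, the cyclohexyl ester shows a number 89.4 percentage points lower from compound 1 to compound 3 (beyond the scatter) as the largest step so far. Nothing available explains either step.

On these data alone, whether cyclohexyl would have any such effect on the amide remains open. So does the outcome for an ester carrying a longer chain or an amine on the carbonyl carbon.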